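The source may hold more compounds than are shown below. What is called first, only, known or untested is meant among the compounds shown, and "the series" means these compounds.

In an assay on isolated protein for displacement of a labelled ligand from 5-hydroxytryptamine receptor 6 (Homo sapiens) (a higher number here means a weaker inhibitor, a lower number a stronger inhibitor), two compounds of the same shared core have been measured. Compound 1 `O=C1CN(C[C@@H]2CCCc3cc(S(=O)(=O)c4cccc(F)c4)ccc32)CCN1` gives 6.31 nM. Within the data shown here, compound 2 `N=C(N)NC(=O)C[C@@H]1CCCc2cc(S(=O)(=O)c3cccc(F)c3)ccc21` gives 0.631 nM, the lowest of the two numbers, with compound 1 as its nearest neighbour, and the single step from one to the other, a 10-fold lower number from compound 1 to compound 2 (1.00 log units; beyond the scatter), is the only comparison that can guide what follows.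

Compound 3 `CC(C)(O)C(=O)NC[C@@H]1CCCc2cc(S(=O)(=O)c3cccc(F)c3)ccc21` carries the change (a group of 7 heavy atoms (4 carbon, 1 nitrogen, 2 oxygen; no ring) in place of a group of 6 heavy atoms (2 carbon, 3 nitrogen, 1 oxygen; no ring), on a saturated chain carbon bound to a saturated ring carbon). The group that enters differs from the one that leaves in the kind of atoms it holds and in the number of hydrogen-bond donors, as the counts above show, and it is also unlike the six-membered ring group of compound 1. Among the measured compounds shown here, the one measured step shows that this position is sensitive to what sits there, and that the group in compound 2 is the one tied to the lower number. For the measured compounds named here, with no closer precedent, a move back toward the weaker end of the measured range seems the more likely outcome, so compound 3 is expected to show a 7.9-fold higher number from compound 2 to compound 3 (0.90 log units; beyond the scatter). Compound 3 is therefore estimated at 5 nM, with a range from 1.5 nM to 20 nM.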

Compound 3, inhibition constant: 2 nM
Estimate against measurement, compound 3: 2.5-fold (0.40 log units) above; measured number inside the range.
By their numbers in this assay, from the lowest: compound 2; then compound 3; then compound 1.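

In this assay, ((1-hydroxy-1-methylethyl)carbonyl)amino gives a 3.2-fold higher number from compound 2 to compound 3 (0.50 log units; beyond the scatter) and also a 3.2-fold lower number from compound 1 to compound 3 (0.50 log units; beyond the scatter), which puts compound 3 in the middle of the three and shows that this position separates more than just two extremes. Among these compounds, an open group holding a single nitrogen still gives a lower number than the 3-oxopiperazin-1-yl ring of compound 1, so the three-nitrogen group of compound 2 is not the only group on this saturated chain carbon that improves on that ring, although it keeps the lowest number so far. Nothing available explains why the three groups fall in this order.

The three groups differ from one another in several ways at once, including their atoms, their rings and their hydrogen-bond donors, so the compounds shown cannot tie the changes in the number to any one of these features. Also open, on these data alone, is how a simple amine, a carboxylic acid or a longer carbon chain on the same carbon would compare, and whether the hydroxyl group in compound 3 contributes at all, which a matching amide without that hydroxyl group could test.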